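The compounds below may be only part of what the source reports. "The series", "measured", "known", "first", "only" and "open" are said of these compounds alone.

Three compounds sharing a core have been examined, with a fourth still to come. Compound 1 `Oc1cccc(-c2cc(-c3cccc(Cl)c3)nc(-c3ccco3)c2)c1`, compound 2 `Oc1cccc(-c2cc(-c3ccsc3)nc(-c3cccc(Cl)c3)c2)c1` and compound 3 `Oc1cccc(-c2cc(-c3ccsc3)nc(-c3ccccc3Cl)c2)c1` were each tested in an ADME assay on HEK293 cells (Homo sapiens) for cytotoxicity, read by CCK-8 assay and cell counting, with a stated time of 2 days; on this read-out lower numbers stand for stronger inhibition and higher numbers for weaker inhibition. In this assay compound 1 gives 2530 nM, compound 2 gives 3180 nM and compound 3 gives 2720 nM. The change from compound 2 to compound 3, (2-chlorophenyl in place of 3-chlorophenyl on an aromatic carbon), made a step of a 1.2-fold lower number from compound 2 to compound 3 (0.07 log units; within the scatter), and the change from compound 2 to compound 1, (furan-2-yl in place of thiophen-3-yl on an aromatic carbon), made a step of a 1.3-fold lower number from compound 2 to compound 1 (0.10 log units; within the scatter). Compound 4 `Oc1cccc(-c2cc(-c3ccco3)nc(-c3ccccc3Cl)c2)c1` has not yet been measured. It differs from compound 3 by furan-2-yl in place of thiophen-3-yl on an aromatic carbon, the same kind of change as from compound 2 to compound 1, though here the place is meta to a 2-chlorophenyl group rather than meta to a 3-chlorophenyl group. Since that earlier step stayed within the scatter, for compound 4 a step of similar size is expected, a 1.2-fold lower number from compound 3 to compound 4 (0.09 log units; within the scatter). Compound 4 is therefore estimated at 2200 nM, likely between 1200 nM and 4000 nM.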

Compound 4, half-maximal inhibitory concentration: 1860 nM
The estimate for compound 4 lay 1.2-fold (0.07 log units) above the measured number, within the range that was stated.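

Replacing thiophen-3-yl with furan-2-yl gives a 1.5-fold lower number from compound 3 to compound 4 (0.17 log units; within the scatter) in this assay, and the two cores agree: the same change on two cores in this assay, a 1.3-fold lower number (0.10 log units; within the scatter) from compound 2 to compound 1 and a 1.5-fold lower number (0.17 log units; within the scatter) from compound 3 to compound 4, 1.2-fold (0.07 log units) apart, within the scatter of two such steps Putting 2-chlorophenyl in place of 3-chlorophenyl gives a 1.4-fold lower number from compound 1 to compound 4 (0.13 log units; within the scatter), and here too the cores agree: the same change on two cores in this assay, a 1.2-fold lower number (0.07 log units; within the scatter) from compound 2 to compound 3 and a 1.4-fold lower number (0.13 log units; within the scatter) from compound 1 to compound 4, 1.2-fold (0.07 log units) apart, within the scatter of two such steps Each change therefore carries over between these two cores, but as every step lies within the scatter, this does not show that either change truly alters the number, and two cores cannot establish a rule for the wider series.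

The compounds shown leave open whether a larger step would appear with an amine or a carboxylic acid in place of the hydroxyl of the 3-hydroxyphenyl group. From the compounds shown here alone, it also remains open whether such a step would carry between cores as these do.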